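A few compounds are considered here, and "the series" means these few. Any claim that something is new, unique, unknown or untested is made for them only; others in the source may bear on it.

Notes on the series. For the measured compounds named here, compound 2 `Cc1cc(C)cc(C(=O)Nc2cccc(-c3oc4cc(-c5ccc(F)cc5)ccc4c(=O)c3O)c2)c1` gives 13500 nM in a functional assay on GTL 16 cells for antiproliferative activity against GTL 16 cell line (Homo sapiens), read by CCK-8 assay, with a stated time of 72 h (a higher number here means a weaker inhibitor, a lower number a stronger inhibitor), the lower of the two numbers so far; compound 1 `O=C(Nc1cccc(-c2oc3cc(-c4ccc(F)cc4)ccc3c(=O)c2O)c1)c1ccccc1F` gives 17400 nM in this assay, and the step of a 1.3-fold lower number from compound 1 to compound 2 (0.11 log units; within the scatter) lies within the scatter. Compound 3 `O=C(Nc1cccc(-c2oc3cc(-c4ccc(F)cc4)ccc3c(=O)c2O)c1)c1ccc([N+](=O)[O-])cc1` is not yet measured. The change from compound 2 to compound 3 is 4-nitrophenyl in place of 3,5-dimethylphenyl on a carbonyl carbon. Going by the values given here, the only measured step at this position, a 1.3-fold lower number from compound 1 to compound 2 (0.11 log units; within the scatter), produced no movement beyond the scatter, and no step carries the group that enters here, so the data give no footing for a shift in either direction. The expected step of a 1.1-fold higher number from compound 2 to compound 3 (0.05 log units; within the scatter) is therefore none beyond the scatter. Compound 3 is estimated at 15000 nM in this assay, with a range from 5000 nM to 45000 nM, the width reflecting that nothing measured bears directly on the entering group.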

Compound 3, half-maximal inhibitory concentration: 18200 nM
Estimate against measurement, compound 3: 1.2-fold (0.08 log units) below; measured number inside the range.
By their numbers in this assay, from the lowest: compounds 2, 1 and 3 (each within the scatter of the next).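

In this assay the swap to 4-nitrophenyl on the carbonyl carbon gives a 1.3-fold higher number from compound 2 to compound 3 (0.13 log units; within the scatter) and, set against the 2-fluorophenyl compound, a 1.0-fold higher number from compound 1 to compound 3 (0.02 log units; within the scatter) as well. The flat reading at this position therefore no longer rests on a single pair: it now spans 2-fluorophenyl, 3,5-dimethylphenyl and 4-nitrophenyl, including an entering group with hydrogen-bond acceptors that 3,5-dimethylphenyl does not have. Nothing at hand accounts for this absence of movement.

Going by these compounds, all three groups are six-membered aromatic rings of carbon only, so it remains open whether an amine, a carboxylic acid or a longer chain on this carbonyl carbon would move the number beyond the scatter. The core is the same throughout, and what changes elsewhere on it would do cannot be read from these compounds.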